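This account rests on a few compounds, and the source may have more. Where it says the series, first, only, none or still open, it means among the compounds named here.

In a functional assay on HeLa cells (Homo sapiens) for inhibition, read by MTT assay, with a stated time of 72 h (on this read-out lower numbers stand for stronger inhibition and higher numbers for weaker inhibition), the measured compounds stand as follows:

compound 1 `O=C(O)/C=C/C(=O)c1ccc(Cl)cc1`: 25400 nM
compound 2 `O=C(O)/C=C/C(=O)c1ccccc1`: 30600 nM
compound 3 `O=C(O)/C=C/C(=O)c1ccc(F)cc1`: 28400 nM

Compound 3 gives the second highest of the three numbers, and all three lie within the scatter of one another. Compound 4 `CC(C)c1ccc(C(=O)/C=C/C(=O)O)cc1` differs from compound 3 by isopropyl in place of fluoro on an aromatic carbon. For the measured compounds named here, the steps that bear on this position are a 1.1-fold lower number from compound 2 to compound 3 (0.03 log units; within the scatter) and a 1.1-fold higher number from compound 1 to compound 3 (0.05 log units; within the scatter), with a 1.2-fold higher number from compound 1 to compound 2 (0.08 log units; within the scatter) completing the set; none of them reached beyond the scatter. Going by the values given here, no measured step puts isopropyl at this carbon, so the expectation rests on the flat picture alone and carries a wide range. From compound 3 to compound 4 the expected step is a 1.1-fold lower number from compound 3 to compound 4 (0.04 log units; within the scatter), none beyond the scatter. Compound 4 is therefore estimated at 26000 nM, between 9000 nM and 70000 nM.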

Compound 4, half-maximal inhibitory concentration: 4900 nM
Compound 4: the middle estimate sits 5.3-fold (0.72 log units) above what was measured; measured number below the stated range.
By their numbers in this assay, from the lowest: compound 4; then compounds 1, 3 and 2 (each within the scatter of the next).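

In this assay this aromatic carbon is not indifferent to its substituent: a 5.8-fold lower number from compound 3 to compound 4 (0.76 log units; beyond the scatter) and a 6.2-fold lower number from compound 2 to compound 4 (0.80 log units; beyond the scatter) and a 5.2-fold lower number from compound 1 to compound 4 (0.71 log units; beyond the scatter) all stand beyond the scatter. The flat picture therefore holds only among hydrogen, fluoro and chloro, and isopropyl is the first group shown to move the number. Nothing at hand accounts for this step. Open, going by these compounds, is what an ethyl, a tert-butyl, a longer chain or an amine would give at this carbon, and whether the drop follows the carbon chain at all.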